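Pyridin-2-yl Carbonyl Variant of a Quinazoline Antagonist

A few compounds are considered here, and "the series" means these few. Any claim that something is new, unique, unknown or untested is made for them only; others in the source may bear on it.

Measured compounds:
compound 1, `COc1cc2nc(N3CCN(C(=O)c4cccs4)[C@H]4CCCC[C@H]43)nc(N)c2cc1OC`, gives 8.78 in a functional assay on spleen for antagonist activity at Alpha-1B adrenergic receptor (Rattus norvegicus); on this read-out lower numbers stand for lower potency and higher numbers for higher potency (the scale is a negative logarithm)
compound 2, `COc1cc2nc(N3CCN(C(=O)c4ccc[nH]4)[C@H]4CCCC[C@H]43)nc(N)c2cc1OC`, gives 8.05 in this assay

Two compounds share one core and differ only in the aromatic ring on the carbonyl carbon. In this assay compound 1 gives 8.78, and compound 2 gives 8.05. Within the data shown here, the single measured step, a number 0.73 log units lower from compound 1 to compound 2 (beyond the scatter), places compound 2 as the lower of the two numbers, with compound 1 the nearer and only comparison.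

Compound 3, `COc1cc2nc(N3CCN(C(=O)c4ccccn4)[C@H]4CCCC[C@H]43)nc(N)c2cc1OC`, has not been measured. It differs from compound 2 in one place: pyridin-2-yl in place of 1H-pyrrol-2-yl on a carbonyl carbon. Among the measured compounds shown here, the only step that bears on this change is the one from the thiophen-2-yl ring to the 1H-pyrrol-2-yl ring, a number 0.73 log units lower from compound 1 to compound 2 (beyond the scatter), which shows that a swap of the aromatic ring on this carbonyl carbon can move the number beyond the scatter. For the measured compounds named here, no measured step tells how a six-membered ring with an acceptor nitrogen behaves at this position, so the direction is uncertain. A small recovery toward compound 1 is expected, a number 0.25 log units higher from compound 2 to compound 3 (within the scatter), in this assay. Compound 3 is therefore estimated at 8.3, within a range from 7.6 to 9.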

Compound 3, negative logarithm of the antagonist equilibrium constant: 8.64
The estimate for compound 3 lay 0.34 log units below the measured number, within the range that was stated.
By their numbers in this assay, from the lowest: compound 2; then compounds 3 and 1 (each within the scatter of the next).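

In this assay, replacing 1H-pyrrol-2-yl with pyridin-2-yl on the carbonyl carbon gives a number 0.59 log units higher from compound 2 to compound 3 (beyond the scatter), so the lower number of compound 2 does not extend to this six-membered aromatic ring. Against the thiophen-2-yl ring, the same ring gives a number 0.14 log units lower from compound 1 to compound 3 (within the scatter), which shows that, among these three compounds, a five-membered ring and a six-membered ring can read alike at this position, and only compound 2 stands apart from both. Nothing shown here gives a reason for the gap between compound 2 and the other two compounds.

The step to compound 3 changes the ring size and removes the hydrogen-bond donor of 1H-pyrrol-2-yl in a single move, and these compounds cannot separate those two changes. On these data alone, how a phenyl ring or a furan-2-yl ring would read on this carbonyl carbon remains open, as does whether an N-methylpyrrol-2-yl ring, which keeps the five-membered ring without the ring hydrogen on nitrogen, would stay with compound 2 or join compound 1 and compound 3.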